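Piperazine dithiocarbamates: chloro versus methyl on the benzyl ring

The compounds below may be only part of what the source reports. "The series", "measured", "known", "first", "only" and "open" are said of these compounds alone.

Measured compounds:
compound 1 `Cc1ccc(Cn2cc(CSC(=S)N3CCN(C(=O)OC(C)(C)C)CC3)nn2)cc1` gives 19700 nM
compound 2 `CC(C)(C)OC(=O)N1CCN(C(=S)SCc2cn(Cc3ccc(Cl)cc3)nn2)CC1` gives 2960 nM
compound 3 `S=C(SCc1cn(Cc2ccc(Cl)cc2)nn1)N1CCNCC1` gives "not determined" (no result reported)

In a functional assay on MCF7 cells (Homo sapiens) for inhibition, read by MTT assay, with a stated time of 72 h (on this read-out lower numbers stand for stronger inhibition and higher numbers for weaker inhibition), compound 2 gives 2960 nM. Compound 1 `Cc1ccc(Cn2cc(CSC(=S)N3CCN(C(=O)OC(C)(C)C)CC3)nn2)cc1` differs from compound 2 by methyl in place of chloro on an aromatic carbon, and in this assay compound 1 gives 19700 nM, so the step of a 6.7-fold higher number from compound 2 to compound 1 (0.82 log units; beyond the scatter) marks a weaker inhibition for the methyl compound.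

Compound 3 `S=C(SCc1cn(Cc2ccc(Cl)cc2)nn1)N1CCNCC1` differs from compound 2 by hydrogen in place of tert-butoxycarbonyl on an amine nitrogen in a ring; in this assay compound 3 gives "not determined" (no result reported), no single number, so the effect of that change is not known. Compound 4 `Cc1ccc(Cn2cc(CSC(=S)N3CCNCC3)nn2)cc1` differs from compound 3 by methyl in place of chloro on an aromatic carbon, the same change as from compound 2 to compound 1, and it appears twice among these compounds.

Going by the values given here, the expectation for compound 4 in this assay is a weaker inhibition than compound 3, by a step of about the size of a 6.7-fold higher number from compound 2 to compound 1 (0.82 log units; beyond the scatter), because the step of a 6.7-fold higher number from compound 2 to compound 1 (0.82 log units; beyond the scatter) is the only evidence for this change. Without a number for compound 3, the estimate for compound 4 rests on compound 1 and its value 19700 nM, with wide uncertainty.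

For compound 4 the estimated value is 25000 nM, expected within 6000 nM to 100000 nM.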

Compound 4, half-maximal inhibitory concentration: 53200 nM
Compound 4: the middle estimate sits 2.1-fold (0.33 log units) below what was measured; the range from low to high includes it.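

In this assay, going by these compounds alone, the one readable step for hydrogen in place of tert-butoxycarbonyl is a 2.7-fold higher number from compound 1 to compound 4 (0.43 log units; beyond the scatter), which lies beyond the scatter and marks weaker inhibition for compound 4 in the 4-methylphenyl pair. The steps from compound 2 to compound 3 and from compound 3 to compound 4 cannot be read, since compound 3 has no result, so the data show neither whether methyl in place of chloro carries over to the core without tert-butoxycarbonyl nor whether loss of tert-butoxycarbonyl carries over to the 4-chlorophenyl pair. No measurement shown here bears on the reason for the step.

Open, from the compounds shown here alone, is how the series would respond to a methoxy group or a fluoro group in place of chloro or methyl on the aromatic ring. Also open, going by these compounds, is how an acetyl group or a longer alkyl chain on the ring amine nitrogen would compare with hydrogen and tert-butoxycarbonyl.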